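Chain Length and Antiproliferative Potency in Three Analogues

The compounds below may be only part of what the source reports. "The series", "measured", "known", "first", "only" and "open" are said of these compounds alone.

Compound 1 `CCCCCCCCCCCCNC[C@@H]1OC[C@H](N)[C@H]1O` gives 41100 nM in a functional assay on A549 cells (Homo sapiens) for antiproliferative activity, read by MTT assay, with a stated time of 72 h; on this read-out lower numbers stand for stronger inhibition and higher numbers for weaker inhibition.
Compound 2 `CCCCCCCCCCNC[C@@H]1OC[C@H](N)[C@@H]1O` gives 47800 nM in this assay.
Compound 3 `CCCCCCCCCCCCNC[C@@H]1OC[C@H](N)[C@@H]1O` gives 5870 nM in this assay.

Compound 3 stands lowest of the three numbers. The step of a 7.0-fold lower number from compound 1 to compound 3 (0.85 log units; beyond the scatter) rests on (the fact that compounds 1 and 3 differ only in the configuration as drawn); the step of an 8.1-fold lower number from compound 2 to compound 3 (0.91 log units; beyond the scatter) shows a modest effect of chain length that lies beyond the scatter. Compound 4 `CCCCCCCCCNC[C@@H]1OC[C@H](N)[C@@H]1O` differs from compound 3 by hydrogen in place of propyl on a saturated chain carbon, nine bonds along the chain from an amine nitrogen. Only the chain-length step from compound 2 to compound 3 bears on this change, and compound 4 cuts the chain further still, so a higher number in this assay, beyond the scatter, is expected. Compound 4 is estimated at 70000 nM, within 25000 nM to 200000 nM. The expected step is a 12-fold higher number from compound 3 to compound 4 (1.08 log units; beyond the scatter).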

Compound 4, half-maximal inhibitory concentration: 22100 nM
Compound 4: the middle estimate sits 3.2-fold (0.50 log units) above what was measured; measured number below the stated range.
By their numbers in this assay, from the lowest: compound 3; then compounds 4, 1 and 2 (each within the scatter of the next, the first and the last beyond it).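

Hydrogen in place of propyl gives a 3.8-fold higher number from compound 3 to compound 4 (0.58 log units; beyond the scatter), yet hydrogen in place of methyl at the same place gives a 2.2-fold lower number from compound 2 to compound 4 (0.34 log units; beyond the scatter). The number therefore does not rise steadily as the chain shortens, and compound 2 goes against such a trend among the three chain lengths. Nothing available accounts for this turn. Going by these compounds, whether a longer chain than that of compound 3 would lower the number further remains open, as does the effect of a chain ending in an amine or a carboxylic acid.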